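Ester in place of sulfonamide on the anilino ring

A few compounds are considered here, and "the series" means these few. Any claim that something is new, unique, unknown or untested is made for them only; others in the source may bear on it.

Of the compounds shown here, three sharing one core have been measured in a functional assay on PANC-1 cells (Homo sapiens) for cytotoxicity, read by MTT assay, with a stated time of 72 h; a higher number here means a weaker inhibitor, a lower number a stronger inhibitor. Compound 1 `COc1ccc(-c2ccc(NC3=CC(=O)c4ncncc4C3=O)cc2)cc1` gives 2300 nM. Compound 2 `O=C1C(Nc2ccc(CO)cc2)=CC(=O)c2ncncc21` gives 1000 nM, and the step of a 2.3-fold lower number from compound 1 to compound 2 (0.36 log units; beyond the scatter) is beyond the scatter. Compound 3 `NS(=O)(=O)c1ccc(NC2=CC(=O)c3ncncc3C2=O)cc1` is reported only as a limit of this assay, > 10000 nM. Compound 3 therefore sits at the limit of > 10000 nM in this assay, at which 1 of the 3 values shown sits, and the steps of an at least 4.3-fold higher number from compound 1 to compound 3 (0.63 log units; beyond the scatter) and an at least 10-fold higher number from compound 2 to compound 3 (1.00 log units; beyond the scatter) both run toward a weaker inhibitor, so compound 3 stands at the weak end of the three.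

Compound 4 `CCOC(=O)c1ccc(NC2=CC(=O)c3ncncc3C2=O)cc1` is not yet measured in this assay. It differs from compound 3 by ethoxycarbonyl in place of sulfamoyl on an aromatic carbon. The two measured steps that bear on the group at this position, from compound 1 and from compound 2 to compound 3, both went toward a higher number when the sulfamoyl group entered. With that group leaving, a step back toward the range of compounds 1 and 2 is expected, though its size is uncertain, and the chance of another limit remains. Compound 4 is estimated at 5000 nM, between 1500 nM and 20000 nM, which means an expected step of an at least 2.0-fold lower number from compound 3 to compound 4 (0.30 log units; that floor lies within the scatter).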

Compound 4, half-maximal inhibitory concentration: 1600 nM
Compound 4: middle estimate off by 3.1-fold (0.49 log units), on the high side; the measured number falls inside the stated range.
By their numbers in this assay, from the lowest: compounds 2, 4 and 1 (each within the scatter of the next, the first and the last beyond it). At a limit, above all of these: compound 3.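

In this assay, among these compounds, sulfamoyl had so far stood out only against hydroxymethyl and 4-methoxyphenyl, and ethoxycarbonyl at the same position now gives an at least 6.2-fold lower number from compound 3 to compound 4 (0.79 log units; beyond the scatter), which shows that this position tolerates a carbonyl-bearing group of similar size. That step is only a floor, since compound 3 stands at a limit of the assay: the limit of > 10000 nM in this assay, at which 1 of the 4 values shown sits.

The two other steps, a 1.6-fold higher number from compound 2 to compound 4 (0.20 log units; within the scatter) and a 1.4-fold lower number from compound 1 to compound 4 (0.16 log units; within the scatter), lie within the scatter, so compound 4 cannot be told apart from either compound, and among the four groups only sulfamoyl stands out.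

The compounds shown leave open whether a carboxylic acid or a primary amide at this position would stay with ethoxycarbonyl or fall with sulfamoyl. They also leave open whether a sulfonamide with a methyl group on its nitrogen would behave like sulfamoyl.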